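This account rests on a few compounds, and the source may have more. Where it says the series, first, only, none or still open, it means among the compounds named here.

Compound 1 `C=C[C@@](C)(/C=C/c1ccc(O)cc1)CC/C=C/C(=O)OCC` carries an ethoxycarbonyl ester on the open chain. In a functional assay on NALM-6 cells (Homo sapiens) for cytotoxicity, with a stated time of 72 h (a lower number here means that less compound is needed, a higher number that more compound is needed for the effect), compound 1 reads only as a limit, > 43400 nM. Compound 2 `C=C[C@@](C)(/C=C/c1ccc(O)cc1)CC/C=C/C(=O)OCc1ccccc1` also reads as a limit in this assay, > 43400 nM. The change between them, (phenyl in place of methyl on a saturated chain carbon bound to an oxygen next to a carbonyl group), gives a step that the two limits leave unreadable from compound 1 to compound 2, since both sit at the limit of > 43400 nM in this assay, at which 2 of the 3 values shown sit. Compound 3 `C=C[C@@](C)(/C=C/c1ccc(O)c(/C=C/C(=O)OCC)c1)CCC=C(C)C` has a different core; the difference between the two cores is not broken down here. In this assay compound 3 gives 20900 nM. Compound 4 `C=C[C@@](C)(/C=C/c1ccc(O)c(/C=C/C(=O)OCc2ccccc2)c1)CCC=C(C)C` repeats the same change on the core of compound 3: phenyl in place of methyl on a saturated chain carbon bound to an oxygen next to a carbonyl group. The earlier pair offers no readable size for this step, so the step from compound 3 to compound 4 is expected near a 1.2-fold higher number from compound 3 to compound 4 (0.08 log units; within the scatter), resting on compound 3 at 20900 nM. Compound 4 is expected to give about 25000 nM, estimated between 8000 nM and 60000 nM.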

Compound 4, half-maximal effective concentration: > 43400 nM
Compound 4: no number, only a limit; the forecaster's own chance of this, stated with the estimate: 40%; middle value at least 1.7-fold (0.23 log units) from the limit.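

On the core of compound 3, the change from ethoxycarbonyl to benzyloxycarbonyl gives an at least 2.0-fold higher number from compound 3 to compound 4 (0.31 log units; beyond the scatter) in this assay. Compound 4 reads only as a limit, so this step has a lower bound and no measured size. The same change on the core of compound 1 cannot be read, so the data neither show nor exclude that the change carries from one core to the other, and almost all readings in this set stop at the same point: the limit of > 43400 nM in this assay, at which 3 of the 4 values shown sit.

Open, from the compounds shown here alone, is how a carboxylic acid or a propyl ester in place of the ethoxycarbonyl group would read on either core. Also open, going by these compounds, is whether any replacement on the core of compound 3 gives a lower number than compound 3 does.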